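The compounds below may be only part of what the source reports. "The series", "measured", "known", "first", "only" and "open" are said of these compounds alone.

Working notes on the series: in a functional assay on B16-F10 cells (Mus musculus) for antiproliferative activity, read by MTT assay, with a stated time of 48 h (on this read-out higher numbers stand for weaker inhibition and lower numbers for stronger inhibition), compound 1 (`CC(=O)N1N=C(c2ccc3ccccc3c2)OC1c1ccc(F)cc1`) gives 4.65 ug/mL and compound 2 (`CC(=O)N1N=C(c2ccc3ccccc3c2)OC1c1ccc([N+](=O)[O-])cc1`) gives 9.32 ug/mL. Among the compounds with values here, these two numbers are the only measurements so far. Their gap is a 2.0-fold higher number from compound 1 to compound 2 (0.30 log units; within the scatter), which lies within the scatter, so compound 2 has no distinct rank against compound 1.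

The next compound to consider is compound 3 (`CC(=O)N1N=C(c2ccc3ccccc3c2)OC1c1ccc(OCc2ccccc2)cc1`). It carries benzyloxy in place of nitro on an aromatic carbon, para to a large group: benzyloxy in place of nitro on an aromatic carbon. The shared core is otherwise unchanged.

Within the data shown here, only one measured step bears on this change, and only indirectly: a 2.0-fold higher number from compound 1 to compound 2 (0.30 log units; within the scatter), with nitro in place of fluoro on an aromatic carbon. Among the measured compounds shown here, no measured compound carries benzyloxy, so the data offer no direct precedent for this group. They give no firm direction for the change either, and a single step within the scatter is weak support for any forecast.

No shift beyond the scatter is therefore expected in this assay. The estimated change is a 1.4-fold lower number from compound 2 to compound 3 (0.16 log units; within the scatter), and this expected step remains within the scatter. The range is kept wide to allow for the untested group. For compound 3 the expected value is 6.5 ug/mL, with an estimated range of 2.5 ug/mL to 17 ug/mL.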

Compound 3, half-maximal inhibitory concentration: 8.08 ug/mL
For compound 3 the middle estimate is 1.2-fold (0.09 log units) below the measured one; low and high end bracket the measured number.
By their numbers in this assay, from the lowest: compounds 1, 3 and 2 (each within the scatter of the next).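

At this position, on an aromatic carbon para to a large group, benzyloxy in place of nitro gives a 1.2-fold lower number from compound 2 to compound 3 (0.06 log units; within the scatter) in this assay and benzyloxy in place of fluoro gives a 1.7-fold higher number from compound 1 to compound 3 (0.24 log units; within the scatter) in the same read-out. Within the data shown here, the earlier pair held only fluoro and nitro here, whereas benzyloxy brings 8 heavy atoms and one six-membered aromatic ring of carbon only in place of the 3 heavy atoms and no ring of nitro, and even this change in atom count yields no step beyond the scatter, so the position so far tolerates groups of quite different size without a distinct rank among the three compounds. No evidence on the cause accompanies these numbers.

Still open, going by these compounds, is whether any group at this place separates from the others beyond the scatter, for instance an amine, a carboxylic acid or a longer alkoxy chain. The shared core stays constant across compound 1, compound 2 and compound 3, so these compounds say nothing about a change anywhere else on it.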